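Swapping a nitrile for an oxetanyl amide on the thiophene core

The source may hold more compounds than are shown below. What is called first, only, known or untested is meant among the compounds shown, and "the series" means these compounds.

Compound 1, `NC(=O)c1c(NC(=O)Nc2ccc(Cl)cc2)sc2c1CCN(CC1CCC1)C2`, gives 1360 nM in a functional assay (strain AB) with Danio rerio as the target, read by microscopy, with a stated time of 1 h; a higher number here means that more compound is needed for the effect, a lower number that less compound is needed.
Compound 2, `CCN1CCc2c(sc(NC(=O)Nc3ccc(Cl)cc3)c2C#N)C1`, gives > 25000 nM in this assay.
Compound 3, `CCCN1CCc2c(sc(NC(=O)Nc3ccc(Cl)cc3)c2C(N)=O)C1`, gives 3500 nM in this assay.

Compound 2 stands apart from the other two measured compounds: its result is not a number but a limit of this assay, (the limit of > 25000 nM in this assay, at which 1 of the 3 values shown sits), so only a floor for its half-maximal effective concentration is known. Compound 3 carries a primary amide where compound 2 carries a nitrile, and also a propyl in place of the ethyl, and it gives a measurable value. Among the compounds with values here, no single-change step joins compound 2 to compound 3, so the two values can only be set side by side.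

Compound 4, `CCN1CCc2c(sc(NC(=O)Nc3ccc(Cl)cc3)c2C(=O)NC2COC2)C1`, is not yet measured. It differs from compound 2 as follows: (oxetan-3-yl)carbamoyl in place of cyano on an aromatic carbon. Within the data shown here, the only measured step, a 2.6-fold higher number from compound 1 to compound 3 (0.41 log units; beyond the scatter), concerns the substituent on the ring nitrogen and does not bear on this change. What compound 2 and compound 3 show together suggests that replacing the nitrile by an amide brings the value into the measurable range, so compound 4 is expected to give a lower number than the limit seen for compound 2, a step of an at least 5.0-fold lower number from compound 2 to compound 4 (0.69 log units; beyond the scatter). The estimate for compound 4 is 5000 nM, with a range from 1500 nM to 25000 nM.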

Compound 4, half-maximal effective concentration: > 25000 nM
Compound 4 gave a limit, no number (the forecaster's own chance of this, stated with the estimate: 25%); middle value at least 5.0-fold (0.69 log units) away from the limit.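

Compound 4, like compound 2, gives only a limit and no number in this assay, so the step from compound 2 to compound 4 cannot be read: the limit of > 25000 nM in this assay, at which 2 of the 4 values shown sit.

The compounds shown leave open how far apart compound 2 and compound 4 really lie, and whether (oxetan-3-yl)carbamoyl in place of cyano changes the half-maximal effective concentration at all.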